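Piperidine amide in place of the chloroanilide of compound 2

The source may report more compounds than this note shows. Statements on the series, on what has been measured and on what is new or still open speak of the compounds shown alone.

Compound 2 `N#C/C(=C\c1cc(O)c(O)c([N+](=O)[O-])c1)C(=O)Nc1cccc(Cl)c1` gives 72.7 ug/mL in a functional assay on KB cells (Homo sapiens) for antiproliferative activity, read by MTT assay (on this read-out lower numbers stand for stronger inhibition and higher numbers for weaker inhibition), the highest number among the three measured compounds, although the number for compound 3 lies within the scatter of it. Compound 1 `COc1ccc(NC(=O)/C(C#N)=C/c2cc(O)c(O)c([N+](=O)[O-])c2)cc1` gives 29.2 ug/mL in this assay, and compound 3 `COc1cc(/C=C(\C#N)C(=O)Nc2cccc(Cl)c2)cc([N+](=O)[O-])c1O` gives 56.6 ug/mL. The two measured steps are a 2.5-fold higher number from compound 1 to compound 2 (0.40 log units; beyond the scatter) and a 1.3-fold lower number from compound 2 to compound 3 (0.11 log units; within the scatter).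

Compound 4 `N#C/C(=C\c1cc(O)c(O)c([N+](=O)[O-])c1)C(=O)N1CCCCC1` differs from compound 2 in one place: piperidin-1-yl in place of (3-chlorophenyl)amino on a carbonyl carbon. The step that bears on this change is the one at the same carbonyl carbon, a 2.5-fold higher number from compound 1 to compound 2 (0.40 log units; beyond the scatter), which was modest but beyond the scatter; the other step, a 1.3-fold lower number from compound 2 to compound 3 (0.11 log units; within the scatter), sits on an oxygen of the aromatic ring and stayed within the scatter. Among the compounds with values here, no measured compound carries a non-aromatic ring on this carbonyl, so the direction of the change is not fixed by the data, and only a modest step of either sign is expected. Compound 4 is therefore expected to show a 1.2-fold lower number from compound 2 to compound 4 (0.08 log units; within the scatter), with an estimated value of 60 ug/mL and a range of 25 ug/mL to 150 ug/mL.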

Compound 4, half-maximal inhibitory concentration: > 100 ug/mL
Compound 4: a limit, no number; the forecaster's own chance of this, stated with the estimate: 10%; middle value at least 1.6-fold (0.22 log units) away from the limit.
By their numbers in this assay, from the lowest: compounds 1, 3 and 2 (each within the scatter of the next, the first and the last beyond it). At a limit, above all of these: compound 4.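

In this assay compound 4 gives a limit, > 100 ug/mL, and not a number. This leaves an at least 1.3-fold higher number from compound 2 to compound 4 (0.13 log units; that floor lies within the scatter), so the piperidine amide shows no sign of stronger inhibition than the chloroanilide, although the floor alone does not establish a real loss. Of the changes shown at this carbonyl carbon, this is the only one that removes both the aromatic ring and the hydrogen-bond donor, and the only one that ends at a limit: the limit of > 100 ug/mL in this assay, at which 1 of the 4 values shown sits.

The compounds shown do not separate the loss of the aromatic ring from the loss of the amide hydrogen, since the two leave together. A cyclohexylamino group on the same carbonyl carbon would pair a non-aromatic ring with a retained amide hydrogen, while an N-methyl-3-chloroanilide would pair the aromatic ring with no amide hydrogen.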